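Removing the dimethylamino group from compound 1

This account rests on a few compounds, and the source may have more. Where it says the series, first, only, none or still open, it means among the compounds named here.

Compound 1, with the structure `CCOc1c(N(C)C)cnn(C)c1=O`, was tested in a functional assay on the whole organism (strain Wistar) for inhibition, with Rattus norvegicus as the target, read by paw edema, with stated times of 30 min and 3 h, at a dose of 100 mg/kg by the oral route; a lower number here means a weaker effect, a higher number a stronger effect of the compound at the dose given. In this assay compound 1 gives 49.5%, the higher of the two numbers recorded so far. The other measured compound is compound 2, `CCOc1c(N2CCCCC2)cnn(C)c1=O`, which carries a piperidine ring in place of the dimethylamino group; in this assay compound 2 gives 14.1%, a number clearly lower than that of compound 1, and the gap between the two lies beyond the usual scatter.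

The next compound is compound 3, `CCOc1ccnn(C)c1=O`. Its difference from compound 1 is hydrogen in place of dimethylamino on an aromatic carbon. Within the data shown here, no measured pair shows exactly this change, so its effect can only be guessed from what the two measured compounds suggest. Since the only amine seen so far that differs from dimethylamino lowered the number, it seems more likely that taking the group away altogether also weakens the effect, though a step within the scatter cannot be ruled out. The expected step is a number 19.5 percentage points lower from compound 1 to compound 3 (beyond the scatter). For compound 3 the estimate in this assay is 30%, with a range from 5% to 55%.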

Compound 3, a percentage reported as inhibition, in the whole organism at one dose (the size of the read-out at that dose, not a potency): -12.2%
The estimate for compound 3 lay 42.2 percentage points above the measured number; the measured number lies below the stated range.
By their numbers in this assay, from the lowest: compound 3; then compound 2; then compound 1.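

In this assay, putting hydrogen in place of dimethylamino on the aromatic carbon gives a number 61.7 percentage points lower from compound 1 to compound 3 (beyond the scatter), so at this dose the effect seen with compound 1 does not remain once the group is gone. The earlier compounds compared only two amines, whereas the hydrogen now adds a baseline: compound 2, with its piperidine ring, gives 14.1%, which still stands above compound 3 at -12.2%, a number below zero, and so among these three compounds both amines give higher numbers than hydrogen. The measurements at hand include nothing that gives a reason for this large step.

Three compounds cannot show whether the nitrogen itself matters at this position or whether any group of similar size would serve, and a methoxy group or an ethyl group placed there would help separate those two readings. A plain amino group, a methylamino group or a morpholine ring would also show how the number changes between dimethylamino and piperidine, the two amines seen so far.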